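The compounds below may be only part of what the source reports. "The series", "measured", "known", "first", "only" and "open" are said of these compounds alone.

Measured compounds:
compound 1 `CC(C)(N)C(=O)N[C@H](COCc1ccccc1)c1nnnn1CCCCCNS(C)(=O)=O` — 75 nM in a functional assay on H4 cells for agonist activity at growth hormone secretagogue receptor type 1 (Homo sapiens), read by FLIPR; on this read-out higher numbers stand for an effect only at larger amounts of compound and lower numbers for an effect already at smaller amounts
compound 2 `CCCCNC(=O)CCn1nnnc1[C@@H](COCc1ccccc1)NC(=O)C(C)(C)N` — 42 nM in this assay
compound 3 `CCCCNC(=O)CCCn1nnnc1[C@@H](COCc1ccccc1)NC(=O)C(C)(C)N` — 30 nM in this assay

Compound 3 gives the lowest of the three numbers in this assay. Against compound 2 the gap is small: a 1.4-fold lower number from compound 2 to compound 3 (0.15 log units; within the scatter). Against compound 1 it is larger: a 2.5-fold lower number from compound 1 to compound 3 (0.40 log units; beyond the scatter). The step of a 1.8-fold lower number from compound 1 to compound 2 (0.25 log units; within the scatter) likewise falls within the scatter. Compound 3 therefore cannot be set apart from compound 2 on these numbers.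

Compound 4 `CC(C)(N)C(=O)N[C@H](COCc1ccccc1)c1nnnn1CCC(=O)NCc1ccccc1` differs from compound 3 by benzylcarbamoyl in place of (butylcarbamoyl)methyl on a saturated chain carbon, two bonds along the chain from an aromatic nitrogen. Among the measured compounds shown here, no measured step exchanges a butyl for a benzyl on the amide nitrogen; the closest comparison is the step from compound 2 to compound 3, which alters the length of the chain carrying the carbamoyl at the same place and stays within the scatter, and the replacement of the sulfonamide chain by a carbamoyl chain in compounds 1 to 2 and 1 to 3, which moves the number only modestly. On that basis no step beyond the scatter is expected in this assay; the expected change is a 1.2-fold higher number from compound 3 to compound 4 (0.07 log units; within the scatter). Compound 4 is therefore estimated at 35 nM, with a range of 12 nM to 100 nM.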

Compound 4, half-maximal effective concentration: 51 nM
For compound 4 the middle estimate is 1.5-fold (0.16 log units) below the measured one; low and high end bracket the measured number.
By their numbers in this assay, from the lowest: compounds 3, 2, 4 and 1 (each within the scatter of the next, the first and the last beyond it).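

In this assay, benzylcarbamoyl, with its six-membered aromatic ring of carbon only, fits at this place, on a saturated chain carbon, two bonds along the chain from an aromatic nitrogen, with a 1.7-fold higher number from compound 3 to compound 4 (0.23 log units; within the scatter) as its step from the longer butyl amide chain. Phenyl in place of propyl gives a 1.2-fold higher number from compound 2 to compound 4 (0.08 log units; within the scatter) and the exchange for the sulfonamide chain gives a 1.5-fold lower number from compound 1 to compound 4 (0.17 log units; within the scatter), so a ring on this amide nitrogen is accepted here about as well as the open chains of compounds 1, 2 and 3. No measurement on hand accounts for these steps.

Still open, on these data alone, is how a carboxylic acid or an amine in place of the amide would read at this place. Also open, as far as these compounds go, are a benzyl amide on the longer chain of compound 3 and a fluorine or methoxy group on the phenyl ring.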